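Removing the propargylsulfanyl group from compound 2

A few compounds are considered here, and "the series" means these few. Any claim that something is new, unique, unknown or untested is made for them only; others in the source may bear on it.

Compound 1 `Cc1cc(Nc2cc(-c3ccccc3)[nH]n2)n2nc(SCc3cccc(Br)c3)nc2n1`: > 50000 nM (a limit)
Compound 2 `C#CCSc1nc2nc(C)cc(Nc3cc(-c4ccccc4)[nH]n3)n2n1`: 45700 nM
Compound 3 `Cc1cc(Nc2cc(-c3ccccc3)[nH]n2)n2nc(SCc3cccc4ccccc34)nc2n1`: 36300 nM

All three readings come from an ADME assay on GES1 cells (Homo sapiens) for inhibition, read by MTT assay, with a stated time of 72 h; a lower number here means a stronger inhibitor, a higher number a weaker inhibitor. For the measured compounds named here, compound 2 gives 45700 nM, and its only exact comparison is a 1.3-fold lower number from compound 2 to compound 3 (0.10 log units; within the scatter). Compound 1 gives > 50000 nM, which is a limit of the assay.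

The next step leads to compound 4 `Cc1cc(Nc2cc(-c3ccccc3)[nH]n2)n2ncnc2n1`, and the change is hydrogen in place of propargylsulfanyl on an aromatic carbon. In words, this is hydrogen in place of propargylsulfanyl on an aromatic carbon.

The measured steps bear on this only in part. Each exchanges a group on a saturated chain carbon bound to a sulfur, and none removes the whole sulfur-linked chain. Two of them, an at least 1.0-fold lower number from compound 1 to compound 2 (0.03 log units; that floor lies within the scatter) and an at least 1.3-fold lower number from compound 1 to compound 3 (0.13 log units; that floor lies within the scatter), are only floors. Going by the values given here, the one exact step, a 1.3-fold lower number from compound 2 to compound 3 (0.10 log units; within the scatter), gives no sign of sensitivity to the chain end, so no shift beyond the scatter is expected in this assay. Among the compounds with values here, that expectation is loose, since no measured compound lacks the chain. The expected step is a 1.0-fold lower number from compound 2 to compound 4 (0.01 log units; within the scatter). A report of only a limit is also expected to be quite possible. For compound 4 the estimate is 45000 nM, with an expected range from 20000 nM to 90000 nM.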

Compound 4, half-maximal inhibitory concentration: > 50000 nM
Compound 4 ended at the assay's limit (the forecaster's own chance of this, stated with the estimate: 45%); middle value at least 1.1-fold (0.04 log units) from the limit.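

For the compounds shown here, compound 4 reads only as a limit in this assay, so this is the first view of the position without any sulfur-linked chain, and it gives no exact number. Hydrogen in place of propargylsulfanyl on this aromatic carbon gives an at least 1.0-fold higher number from compound 2 to compound 4 (0.03 log units; that floor lies within the scatter), so taking away the whole group, and not just exchanging the chain end, shows no stronger inhibition, while the true size of the step stays unknown. The step from compound 1 to compound 4 cannot be read, and the upper end of the series is now bounded by a shared ceiling rather than resolved into numbers: the limit of > 50000 nM in this assay, at which 2 of the 4 values shown sit.

Still open, going by these compounds, is whether any other group on this aromatic carbon, such as an amine, a carboxylic acid or a methylsulfanyl group, would give an exact number and a step beyond the scatter. Also open, on these data alone, is whether the sulfur atom itself matters here, which a longer carbon chain joined directly to this aromatic carbon or an ether-linked propargyl group could test against compound 2 in this assay.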